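Ethoxyphenyl for fluorophenyl on the nitrile-bearing core

A few compounds are considered here, and "the series" means these few. Any claim that something is new, unique, unknown or untested is made for them only; others in the source may bear on it.

Two compounds of this series carry numbers in a physicochemical assay for lipophilicity, read by HPLC, at pH 7.5; on this read-out higher numbers stand for higher lipophilicity and lower numbers for lower lipophilicity. Compound 1 `CCOc1ccccc1-c1ccc(-c2nc3cnccc3c(C[C@H](C)C(=O)O)c2C#N)cc1` gives 2.2 in this assay. Compound 2 `CC[C@@H](Nc1c(C#N)c(-c2ccc(-c3ccc(F)cc3)cc2)nc2cnccc12)C(N)=O` gives 2.7 in this assay, which is the highest of the two numbers shown; compound 1 sits lower, a gap beyond the usual scatter. Among the measured compounds shown here, no pair of measured compounds differs in a single place, so no measured step exists to lean on.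

Compound 3 `CCOc1ccccc1-c1ccc(-c2nc3cnccc3c(N[C@H](CC)C(N)=O)c2C#N)cc1` is not yet measured in this assay. It differs from compound 2 as follows: 2-ethoxyphenyl in place of 4-fluorophenyl on an aromatic carbon. The group that enters is larger than the one that leaves and brings one hydrogen-bond acceptor. The step from compound 2 to compound 3 is expected to be small and upward, a number 0.20 log units higher from compound 2 to compound 3 (within the scatter), possibly within the scatter. Compound 3 is therefore expected to give about 2.9, within a range from 2.5 to 3.4.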

Compound 3, distribution coefficient: 3
Compound 3: the middle estimate sits 0.10 log units below what was measured, within the range that was stated.
By their numbers in this assay, from the lowest: compound 1; then compounds 2 and 3 (each within the scatter of the next).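

In this assay, 2-ethoxyphenyl in place of 4-fluorophenyl on an aromatic carbon, para to a large group, gives a number 0.30 log units higher from compound 2 to compound 3 (within the scatter), so at this position the larger group with its hydrogen-bond acceptor cannot be separated from 4-fluorophenyl on this read-out. Among the compounds shown here, with 2-ethoxyphenyl held constant, (1-carbamoylpropyl)amino in place of 2-carboxypropyl on an aromatic carbon gives a number 0.80 log units higher from compound 1 to compound 3 (beyond the scatter), the only single-place change here that lies beyond the scatter. No measured data account for either step.

From the compounds shown here alone, what an unsubstituted phenyl or a longer alkoxy chain such as propoxy would give at this position remains open. Also open, going by these compounds, is whether a primary amine or a carboxylic acid on the side chain of compound 3 would give a similar step.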